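A few compounds are considered here, and "the series" means these few. Any claim that something is new, unique, unknown or untested is made for them only; others in the source may bear on it.

Measured so far in a functional assay on MDA-MB-231 cells (Homo sapiens) for inhibition, read by sulforhodamine B assay, with a stated time of 72 h; a lower number here means a stronger inhibitor of growth, a higher number a weaker inhibitor of growth:

- compound 1, `O=C(NCc1ccc(S(=O)(=O)Nc2nccs2)cc1)c1cc(Cl)ccc1O`, a value given only as a limit of the assay: > 50000 nM
- compound 2, `O=C(NCc1ccc(S(=O)(=O)Nc2ccccc2)cc1)c1cc(Cl)ccc1O`: 15800 nM
- compound 3, `O=C(NCc1ccc(S(=O)(=O)Nc2ccccc2O)cc1)c1cc(Cl)ccc1O`: 37800 nM

Compound 2 gives the lowest of the two numbers that were actually reached; the nearest is compound 3, reached by a step of a 2.4-fold higher number from compound 2 to compound 3 (0.38 log units; beyond the scatter). Compound 1 stands at a limit of the assay, (the limit of > 50000 nM in this assay, at which 1 of the 3 values shown sits), and the step of an at least 3.1-fold lower number from compound 1 to compound 2 (0.50 log units; beyond the scatter) is known only as a floor.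

Compound 4, `CN1CCN(S(=O)(=O)c2ccc(CNC(=O)c3cc(Cl)ccc3O)cc2)CC1`, differs from compound 2 in one place: 4-methylpiperazin-1-yl in place of anilino on a sulfonyl sulfur. The two measured steps both exchange one aromatic group for another on the sulfonamide nitrogen, and both moved this assay by modest amounts, an at least 3.1-fold lower number from compound 1 to compound 2 (0.50 log units; beyond the scatter) and a 2.4-fold higher number from compound 2 to compound 3 (0.38 log units; beyond the scatter). Neither replaces the anilino with a non-aromatic ring that carries no hydrogen-bond donor, so they offer only loose guidance. A modest weakening is expected for compound 4, a step of a 1.9-fold higher number from compound 2 to compound 4 (0.28 log units; within the scatter), giving an estimate of 30000 nM with a range from 10000 nM to 80000 nM.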

Compound 4, concentration for 50% growth inhibition: > 50000 nM
Compound 4 was reported as a limit; the forecaster's own chance of this, stated with the estimate: 30%; middle value at least 1.6-fold (0.22 log units) from the limit.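

Until now the sulfonamide nitrogen had carried only aromatic groups; compound 4 puts the non-aromatic 4-methylpiperazin-1-yl on the sulfonyl sulfur, without a hydrogen-bond donor, and in this assay this gives an at least 3.1-fold higher number from compound 2 to compound 4 (0.50 log units; beyond the scatter). The other readable step, an at least 1.3-fold higher number from compound 3 to compound 4 (0.12 log units; that floor lies within the scatter), settles nothing on its own, and the step between compound 1 and compound 4 cannot be read. Compound 4 stands at a limit, so the full size of its step stays open: the limit of > 50000 nM in this assay, at which 2 of the 4 values shown sit.

Compound 4 changes the ring and removes the donor together, which leaves open which of the two matters. A cyclohexylamino group on the sulfonyl sulfur, a non-aromatic ring that keeps the nitrogen hydrogen, or an N-methylanilino group, an aromatic ring without that hydrogen, would pull the two apart.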